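A few compounds are considered here, and "the series" means these few. Any claim that something is new, unique, unknown or untested is made for them only; others in the source may bear on it.

In a functional assay on HepG2 cells (Homo sapiens) for antiproliferative activity, read by MTT assay, with a stated time of 48 h (a higher number here means a weaker inhibitor, a lower number a stronger inhibitor), three compounds built on a shared core have been measured. Compound 1 (`COc1cccc(/C=C/C(=O)N2Cc3ccccc3[C@@H](OCc3ccccc3)[C@@H]2CO)c1OC`) gives 31000 nM, compound 2 (`O=C(/C=C/c1ccc([N+](=O)[O-])cc1)N1Cc2ccccc2[C@@H](OCc2ccccc2)[C@@H]1CO`) gives 5370 nM, and compound 3 (`Cc1ccc(S(=O)(=O)NCC(=O)N2Cc3ccccc3[C@@H](OCc3ccccc3)[C@@H]2CO)cc1`) gives 5050 nM. Compound 3 therefore stands level with compound 2, within the scatter, and apart from compound 1, beyond the scatter.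

Compound 4 (`Cc1ccc(S(=O)(=O)N[C@@H](C)C(=O)N2Cc3ccccc3[C@@H](OCc3ccccc3)[C@@H]2CO)cc1`) differs from compound 3 by a single change: methyl in place of hydrogen on a saturated chain carbon bound to a carbonyl carbon and a sulfonamide nitrogen. Among the measured compounds shown here, the only measured step is modest, a 5.8-fold lower number from compound 1 to compound 2 (0.76 log units; beyond the scatter), and it concerns 4-nitrophenyl in place of 2,3-dimethoxyphenyl, not this chain carbon. For the measured compounds named here, no measured step bears directly on the change, so the data suggest no direction, and no shift beyond the scatter is expected. The expected step is a 1.0-fold lower number from compound 3 to compound 4 (0.00 log units; within the scatter). In this assay the estimated value for compound 4 is 5000 nM, with an expected range from 2000 nM to 13000 nM.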

Compound 4, half-maximal inhibitory concentration: 5370 nM
Estimate against measurement, compound 4: 1.1-fold (0.03 log units) below, within the range that was stated.
By their numbers in this assay, from the lowest: compounds 3, 2 and 4 (each within the scatter of the next); then compound 1.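

In this assay, methyl in place of hydrogen on the saturated chain carbon bound to a carbonyl carbon and a sulfonamide nitrogen gives a 1.1-fold higher number from compound 3 to compound 4 (0.03 log units; within the scatter). Among the compounds shown here, this is the first measured change at this position, and it shows that the position accepts this single added carbon with no shift beyond the scatter, whereas the only earlier step concerned the aryl group on the double-bonded chain. Nothing available explains this flat result.

A single methyl leaves open what a longer chain, a phenyl ring, an amine or a carboxylic acid on this same carbon would do. It also leaves open whether the flat result would hold with any other group on the shared core.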